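The source may hold more compounds than are shown below. What is called first, only, known or untested is meant among the compounds shown, and "the series" means these compounds.

Measured compounds:
- Compound 1, `O=c1[nH]c(=O)n([C@@H]2O[C@H](COP(=O)(O)OP(=O)(O)OP(=O)(O)O)[C@@H](O)[C@H]2O)cc1Br` — in an in vitro functional assay on 1321-N1 cells for agonist activity at P2Y purinoceptor 6 (Homo sapiens) (a higher number here means that more compound is needed for the effect, a lower number that less compound is needed), compound 1 gives 291 nM
- Compound 2, `O=c1[nH]c(=O)n([C@@H]2O[C@H](COP(=O)(O)OP(=O)(O)O)[C@@H](O)[C@H]2O)cc1Br` — compound 2 gives 151 nM
- Compound 3, `Cn1c(=O)ccn([C@@H]2O[C@H](COP(=O)(O)O)[C@@H](O)[C@H]2O)c1=O` — compound 3 gives >= 100000 nM, which is a limit of this assay, not a number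

Compound 2 gives the lowest of the two numbers shown in this assay; its nearest neighbour is compound 1, and the step of a 1.9-fold lower number from compound 1 to compound 2 (0.28 log units; within the scatter) lies within the scatter, so no order between the two can be claimed. Compound 3 stands at the limit of >= 100000 nM in this assay, at which 1 of the 3 values shown sits.

Compound 4, `O=c1[nH]c(=O)n([C@@H]2O[C@H](COP(=O)(O)O)[C@@H](O)[C@H]2O)cc1Br`, is not yet measured. It differs from compound 2 in one place: a hydrogen atom in place of a group of 4 heavy atoms (3 oxygen, 1 phosphorus; no ring), on an oxygen. For the measured compounds named here, the only measured step of the same kind is a 1.9-fold lower number from compound 1 to compound 2 (0.28 log units; within the scatter), which did not exceed the scatter. Going by the values given here, that step, however, went from a chain of three phosphorus-bearing units to two; the step to compound 4 goes further, and compound 3, the only other compound with a single such unit, is reported as a limit. A marked loss is therefore expected for compound 4, though its size is poorly anchored.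

The expected step is a 130-fold higher number from compound 2 to compound 4 (2.12 log units; beyond the scatter). For compound 4 the estimate in this assay is 20000 nM, with a range of 3000 nM to 100000 nM.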

Compound 4, half-maximal effective concentration: > 1000 nM
Compound 4: only a limit was reported; the forecaster's own chance of this, stated with the estimate: 35%; the middle value lies beyond the limit too.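

In this assay compound 4 is reported only as a limit, > 1000 nM, so its true position remains unfixed. Even so, the change now reads beyond the scatter: a hydrogen atom in place of the group of 4 heavy atoms (3 oxygen, 1 phosphorus; no ring), on an oxygen, gives an at least 6.6-fold higher number from compound 2 to compound 4 (0.82 log units; beyond the scatter), whereas the same kind of change earlier gave a 1.9-fold lower number from compound 1 to compound 2 (0.28 log units; within the scatter), within the scatter. Replacing the larger group gives an at least 3.4-fold higher number from compound 1 to compound 4 (0.53 log units; beyond the scatter), so at this oxygen the single phosphorus-bearing unit is the only chain length shown to lose ground.

Going by these compounds, the full size of the loss stays open, as only a lower bound is available. Also open, on these data alone, is whether a longer chain of phosphorus-bearing units, or a sulfur atom in place of an oxygen on the chain, would hold the number.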